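The compounds below may be only part of what the source reports. "The series", "measured", "known", "first", "only" and "open" are said of these compounds alone.

Measured so far in a functional assay on PC-12 cells (Rattus norvegicus) for cytotoxicity, read by MTT assay, with stated times of 2 h and 24 h, tested at 10 uM; on this read-out higher numbers stand for a stronger effect at the one concentration tested and lower numbers for a weaker effect: compound 1 `CCc1ccc(-n2nc(-c3ccc(C(F)(F)F)cc3O)nc2-c2ccccc2O)cc1` gives 107%; compound 2 `Oc1cc(C(F)(F)F)ccc1-c1nc(-c2ccccc2O)n(-c2ccc(Cl)cc2)n1` gives 96.1%; compound 3 `COc1ccc(-n2nc(-c3ccc(C(F)(F)F)cc3O)nc2-c2ccccc2O)cc1` gives 98.9%.

Compound 3 stands second highest of these three: its nearest neighbour is compound 2, with a number 2.8 percentage points higher from compound 2 to compound 3 (within the scatter), and its furthest is compound 1, with a number 8.1 percentage points lower from compound 1 to compound 3 (within the scatter). Compound 4 `Oc1cc(C(F)(F)F)ccc1-c1nc(-c2ccccc2O)n(-c2cccc(F)c2)n1` differs from compound 3 by 3-fluorophenyl in place of 4-methoxyphenyl on an aromatic nitrogen. The three measured steps all swap the group on this same aromatic nitrogen, and only a number 10.9 percentage points lower from compound 1 to compound 2 (beyond the scatter) went beyond the scatter; the others, a number 8.1 percentage points lower from compound 1 to compound 3 (within the scatter) and a number 2.8 percentage points higher from compound 2 to compound 3 (within the scatter), stayed within it. The exchange of methoxy for fluoro on that ring is therefore expected to give a step within the scatter, an expected a number 2.9 percentage points lower from compound 3 to compound 4 (within the scatter). Compound 4 is estimated at 96%, within 85% to 107%.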

Compound 4, a percentage reported as activity, at one concentration (the size of the read-out at that concentration, not a potency): 98.3%
Beside the measured number, compound 4's estimate is 2.3 percentage points below it; the measured number falls inside the stated range.
By their numbers in this assay, from the lowest: compounds 2, 4, 3 and 1 (each within the scatter of the next, the first and the last beyond it).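

Compound 4 is the only one of the four with a 3-fluorophenyl on this aromatic nitrogen, and in this assay that group stays within the scatter of all three others (a number 0.6 percentage points lower from compound 3 to compound 4 (within the scatter); a number 2.2 percentage points higher from compound 2 to compound 4 (within the scatter); a number 8.7 percentage points lower from compound 1 to compound 4 (within the scatter)). The position therefore accepts 3-fluorophenyl as well as 4-methoxyphenyl, 4-chlorophenyl and 4-ethylphenyl with no clear change in the number. Nothing available explains this.

From the compounds shown here alone, whether an amine, a carboxylic acid or a longer chain on this ring would move the number beyond the scatter remains open.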